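This account rests on a few compounds, and the source may have more. Where it says the series, first, only, none or still open, it means among the compounds named here.

Measured compounds in an in vitro assay on BHK cells for inhibition of Glucagon receptor (Homo sapiens); a higher number here means a weaker inhibitor, a lower number a stronger inhibitor:

- Compound 1 `CC(C)(C)[C@H]1CC[C@H](N(Cc2ccc(C(=O)NCCC(=O)O)cc2)C(=O)Nc2ccc(C#N)cc2)CC1`: 1050 nM
- Compound 2 `O=C(O)CCNC(=O)c1ccc(CN(C(=O)Nc2ccc(OC(F)(F)F)cc2)C2CCC(C(=O)NCC3CC3)CC2)cc1`: > 10000 nM
- Compound 3 `CC(C)(C)C1CCC(N(Cc2ccc(C(=O)NCCCC(=O)O)cc2)C(=O)Nc2ccc(OC(F)(F)F)cc2)CC1`: > 10000 nM

Among the measured compounds shown here, compound 1 is the only member of the set with a numerical value. For compound 2 the assay gives only a limit, > 10000 nM. For compound 3 the result is likewise only a limit, > 10000 nM. Compound 3 therefore does not stand anywhere on a scale of numbers; it sits at the same limit as compound 2, which is where two of the three values shown sit (the limit of > 10000 nM in this assay, at which 2 of the 3 values shown sit). For the measured compounds named here, no pair of measured compounds differs in a single place, so no step can be read from the measured set.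

Compound 4 `CC(C)(CC(=O)O)NC(=O)c1ccc(CN(C(=O)Nc2ccc(OC(F)(F)F)cc2)C2CCC(C(C)(C)C)CC2)cc1` is the unmeasured compound. It differs from compound 3 in one place: 1-(carboxymethyl)-1-methylethyl in place of 3-carboxypropyl on an amide-type nitrogen. The rest of compound 3, including its core and both aryl groups, is kept.

Going by the values given here, with compound 3 resting at a limit and no measured step to lean on, the change from the 3-carboxypropyl chain to the 1-(carboxymethyl)-1-methylethyl chain is expected to give no shift that can be told from the scatter, and the step that the limit leaves unreadable from compound 3 to compound 4 is set accordingly as an estimate. Compound 4 is thus expected near 12000 nM, within about 3000 nM to 40000 nM, with a substantial chance that this assay again reports only a limit.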

Compound 4, half-maximal inhibitory concentration: > 10000 nM
Compound 4 was reported as a limit; the forecaster's own chance of this, stated with the estimate: 65%; the middle value lies beyond the limit too.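

Compound 3 and compound 4 are both reported only as limits in this assay, so no step can be read for 1-(carboxymethyl)-1-methylethyl in place of 3-carboxypropyl on the amide-type nitrogen. The compounds shown leave open whether this change of chain alters inhibition at all, with most values resting at one limit: the limit of > 10000 nM in this assay, at which 3 of the 4 values shown sit.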